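The source may report more compounds than this note shows. Statements on the series, on what has been measured and on what is new or still open speak of the compounds shown alone.

Working notes on the series. Going by the values given here, compound 1 `Nc1cc(N)c2nc(-c3ccccc3)c(Oc3ccc(Cl)c(Cl)c3)nc2c1` is the one member with a number in a functional assay on COLO 205 cells (Homo sapiens) for inhibition, read by sulforhodamine B assay, with a stated time of 48 h; on this read-out higher numbers stand for weaker inhibition of growth and lower numbers for stronger inhibition of growth: compound 1 gives 67600 nM. Compound 2 `CCOC(=O)[C@H](CCC(=O)O)NC(=O)c1ccc(Sc2nc3cc(N)cc(N)c3nc2-c2ccccc2)cc1` returns only a limit, < 100000 nM, in this assay. Compound 3 `CCOC(=O)[C@H](CCC(=O)O)NC(=O)c1ccc(Oc2nc3cc(N)cc(N)c3nc2-c2ccccc2)cc1` likewise returns only a limit, < 100000 nM, in this assay. So compound 1 stands alone on the numbers, the other two values shown being limits (the limit of < 100000 nM in this assay, at which 2 of the 3 values shown sit), and no step between measured compounds is available. Compound 4 `Nc1cc(N)c2nc(-c3ccccc3)c(Oc3ccc(F)cc3)nc2c1` has not been measured in this assay. It differs from compound 1 by 4-fluorophenyl in place of 3,4-dichlorophenyl on an oxygen on an aromatic ring. Among the compounds with values here, with no measured step to lean on, the expected step from compound 1 to compound 4 in this assay is a 1.2-fold higher number from compound 1 to compound 4 (0.07 log units; within the scatter), none beyond the scatter or a slight weakening. Compound 4 is thus estimated at 80000 nM, within 25000 nM to 200000 nM, with some chance that only a limit is reported.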

Compound 4, concentration for total growth inhibition: 36300 nM
For compound 4 the middle estimate is 2.2-fold (0.34 log units) above the measured one, and the stated range covers the measured number.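

On an oxygen on an aromatic ring, 4-fluorophenyl in place of 3,4-dichlorophenyl gives a 1.9-fold lower number from compound 1 to compound 4 (0.27 log units; within the scatter) in this assay. Going by these compounds alone, this is the first readable step, and on this read-out it does not separate the two groups. Nothing available accounts for the step.

From the compounds shown here alone, whether a carboxylic acid or an amine on this phenyl ring, or a longer alkyl chain in its place, would separate from compound 1 stays open. The compounds shown include no step beyond the scatter at this position.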